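Swapping the thiadiazole for an oxadiazole on a chromone thioether

The source may report more compounds than this note shows. Statements on the series, on what has been measured and on what is new or still open speak of the compounds shown alone.

Measured compounds, one per line:
Compound 1, `Cc1nnc(SCc2cc(=O)c3ccccc3o2)o1`, in a functional assay on MCF7 cells (Homo sapiens) for cytotoxicity, read by MTT assay, with a stated time of 72 h (a higher number here means a weaker inhibitor, a lower number a stronger inhibitor), compound 1 gives > 25000 nM, a limit of the assay.
Compound 2, `Cc1ccc2oc(CSc3nnc(N)s3)cc(=O)c2c1`, in this assay compound 2 gives > 25000 nM, a limit of the assay.
Compound 3, `Nc1nnc(SCc2cc(=O)c3cc(Cl)ccc3o2)s1`, in this assay compound 3 gives > 25000 nM, a limit of the assay.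

Compound 2 therefore stands at the limit of this assay; no number is known for it, only that it lies beyond what the assay can report. The same is true of every value shown, as summarised in the limit of > 25000 nM in this assay, at which 3 of the 3 values shown sit.

Compound 4, `Cc1ccc2oc(CSc3nnc(C)o3)cc(=O)c2c1`, is not yet measured. It differs from compound 2 in one place: 5-methyl-1,3,4-oxadiazol-2-yl in place of 5-amino-1,3,4-thiadiazol-2-yl on a sulfur.

For the measured compounds named here, only one measured step is available, a step that the two limits leave unreadable from compound 2 to compound 3, and it is unreadable, since both ends sit at the limit. It does not concern the same part of the molecule as the change to compound 4, so it offers no direct guidance on the size or direction of the step in this assay. Compound 1 already carries the 5-methyl-1,3,4-oxadiazol-2-yl group on the sulfur and also sits at the limit, which is the closest point of comparison.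

Given that, compound 4 is expected to remain at the limit, with an estimated 40000 nM spanning 12000 nM to 150000 nM. The expected step from compound 2 is a step that the limit leaves unreadable from compound 2 to compound 4, meaning no change beyond the scatter.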

Compound 4, half-maximal inhibitory concentration: > 25000 nM
Compound 4: only a limit was reported; the forecaster's own chance of this, stated with the estimate: 85%; the middle value does not contradict the limit.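

No step to compound 4, whether from compound 1 or from compound 2, can be read, because every result is a limit and not a number: the limit of > 25000 nM in this assay, at which 4 of the 4 values shown sit.

The compounds shown leave open how far beyond that limit each one lies, and whether swapping 5-amino-1,3,4-thiadiazol-2-yl for 5-methyl-1,3,4-oxadiazol-2-yl changes potency at all in this assay.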